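The source may hold more compounds than are shown below. What is called first, only, known or untested is meant among the compounds shown, and "the series" means these compounds.

Three compounds that share one core and differ only in the aryl group attached to the carbonyl carbon have been tested in a functional assay on MCF7 cells (Homo sapiens) for antiproliferative activity, read by MTT assay, with a stated time of 72 h; on this read-out higher numbers stand for weaker inhibition and lower numbers for stronger inhibition. Compound 3 `O=C(Nc1ccc(Cl)c(-c2nnc3c(Cl)cccn23)c1)c1ccc(Cl)cc1` gives 58400 nM, the lower of the two numbers reported. Compound 2 `O=C(Nc1ccc(Cl)c(-c2nnc3c(Cl)cccn23)c1)c1ccccn1` gives 96400 nM, and the step of a 1.7-fold lower number from compound 2 to compound 3 (0.22 log units; within the scatter) stays within the scatter. Compound 1 `O=C(Nc1ccc(Cl)c(-c2nnc3c(Cl)cccn23)c1)c1ccc(F)cc1Cl` yields only a limit, > 100000 nM. Compound 4 `O=C(Nc1ccc(Cl)c(-c2nnc3c(Cl)cccn23)c1)c1cccc(Cl)c1` carries the change (3-chlorophenyl in place of 4-chlorophenyl on a carbonyl carbon). The earlier aryl swaps on that same carbonyl carbon, an at least 1.7-fold lower number from compound 1 to compound 3 (0.23 log units; that floor lies within the scatter) and an at least 1.0-fold lower number from compound 1 to compound 2 (0.01 log units; that floor lies within the scatter), were small as well, none leaving the scatter. Exchanging 4-chlorophenyl for 3-chlorophenyl is therefore expected to produce no step beyond the scatter, an expected 1.0-fold higher number from compound 3 to compound 4 (0.01 log units; within the scatter). Compound 4 is estimated at 60000 nM, within 25000 nM to 150000 nM.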

Compound 4, half-maximal inhibitory concentration: 71900 nM
The estimate for compound 4 lay 1.2-fold (0.08 log units) below the measured number; low and high end bracket the measured number.
By their numbers in this assay, from the lowest: compounds 3, 4 and 2 (each within the scatter of the next). At a limit, above all of these: compound 1.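

Swapping 4-chlorophenyl for 3-chlorophenyl on this carbonyl carbon keeps the same atoms and only rearranges them, and it gives a 1.2-fold higher number from compound 3 to compound 4 (0.09 log units; within the scatter), so in this assay this rearrangement of the chlorophenyl group leaves the number within the scatter. The comparisons with the other aryl groups also stay inside it, at a 1.3-fold lower number from compound 2 to compound 4 (0.13 log units; within the scatter) and an at least 1.3-fold lower number from compound 1 to compound 4 (0.14 log units; that floor lies within the scatter). Compound 1 remains a limit: the limit of > 100000 nM in this assay, at which 1 of the 4 values shown sits.

From the compounds shown here alone, whether any group on this carbon can move the number beyond the scatter stays open. An aryl group carrying an amine or a carboxylic acid, or a longer chain in place of the aryl group, could test that.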